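Thiazole for pyrazine at the ether-linked arm

This account rests on a few compounds, and the source may have more. Where it says the series, first, only, none or still open, it means among the compounds named here.

Of the compounds shown here, three sharing one core have been measured in a functional assay on HEK293 cells for positive allosteric modulation of metabotropic glutamate receptor 5 (Homo sapiens), read by FLIPR and calcium flux; on this read-out lower numbers stand for an effect already at smaller amounts and higher numbers for an effect only at larger amounts of compound. Compound 1 `O=C(COCc1ccncc1)N1CCN(c2ccc(Cl)cc2F)CC1` gives 600 nM, compound 2 `O=C(COCc1ccccn1)N1CCN(c2ccc(Cl)cc2Cl)CC1` gives 310 nM, and compound 3 `O=C(COCc1cnccn1)N1CCN(c2ccc(Cl)cc2Cl)CC1` gives 5200 nM, the highest of the three numbers. Among the measured compounds shown here, the only single-point step recorded is a 17-fold higher number from compound 2 to compound 3 (1.22 log units; beyond the scatter), which shows that exchanging the aromatic ring at this position can shift the read-out strongly. Compound 4 `O=C(COCc1cncs1)N1CCN(c2ccc(Cl)cc2Cl)CC1` differs from compound 3 by 1,3-thiazol-5-yl in place of pyrazin-2-yl on a saturated chain carbon bound to an oxygen on a saturated carbon. For the measured compounds named here, no measured step covers a thiazole here, so the direction is open; given the large effect of the one ring exchange recorded, a sizable move is plausible but unproven. Compound 4 is therefore expected to give roughly 2500 nM, within 600 nM to 10000 nM, corresponding to an estimated 2.1-fold lower number from compound 3 to compound 4 (0.32 log units; beyond the scatter).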

Compound 4, half-maximal effective concentration: 1280 nM
Compound 4: the middle estimate sits 2.0-fold (0.29 log units) above what was measured; the range from low to high includes it.
By their numbers in this assay, from the lowest: compounds 2 and 1 (each within the scatter of the next); then compound 4; then compound 3.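

Replacing pyrazin-2-yl with 1,3-thiazol-5-yl on this saturated chain carbon gives a 4.1-fold lower number from compound 3 to compound 4 (0.61 log units; beyond the scatter) and so recovers part of the ground lost with the pyrazine. Pyridin-2-yl still keeps the lower number, as the thiazole brings a 4.1-fold higher number from compound 2 to compound 4 (0.62 log units; beyond the scatter) at the same place. Nothing measured here explains this order of the three rings.

The compounds shown leave open whether the ring size or the sulfur accounts for the thiazole's shift. On these data alone, how a plain phenyl ring, a pyrimidin-2-yl ring or a thiazole carrying an amine would read at this place also remains unknown.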